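Swapping the sulfonyl aryl group on a boronic acid series

The compounds below may be only part of what the source reports. "The series", "measured", "known", "first", "only" and "open" are said of these compounds alone.

Three boronic acids share a common core carrying a sulfonamide, and they were tested for slowing the growth of a breast-cancer cell line. Compound 1 `CC(C)C[C@H](NC(=O)CCSc1cc(NS(=O)(=O)c2cccs2)c2ccccc2c1O)B(O)O` gives 4450 nM in a functional assay on MDA-MB-231 cells (Homo sapiens) for antiproliferative activity, read by sulforhodamine B assay, with a stated time of 72 h; a higher number here means a weaker inhibitor, a lower number a stronger inhibitor. Compound 2 `CC(=O)Nc1ccc(S(=O)(=O)Nc2cc(SCCC(=O)N[C@@H](CC(C)C)B(O)O)c(O)c3ccccc23)cc1` differs from it by one change 4-acetamidophenyl in place of thiophen-2-yl on a sulfonyl sulfur and gives 2120 nM in this assay, a step of a 2.1-fold lower number from compound 1 to compound 2 (0.32 log units; beyond the scatter). Compound 3 `CC(C)C[C@H](NC(=O)C(C)Sc1cc(NS(=O)(=O)c2cccs2)c2ccccc2c1O)B(O)O` has the same atoms as compound 1 joined differently; the difference between the two cores is not broken down here. In this assay compound 3 gives 7450 nM; this sits within the scatter of compound 1 but is beyond it relative to compound 2.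

Compound 4 `CC(=O)Nc1ccc(S(=O)(=O)Nc2cc(SC(C)C(=O)N[C@@H](CC(C)C)B(O)O)c(O)c3ccccc23)cc1` is not yet measured. It stands to compound 3 as compound 2 stands to compound 1, with the same change at the same place (4-acetamidophenyl in place of thiophen-2-yl on a sulfonyl sulfur). Because the earlier step was a 2.1-fold lower number from compound 1 to compound 2 (0.32 log units; beyond the scatter), a step of similar size is expected from compound 3 to compound 4, namely a 2.1-fold lower number from compound 3 to compound 4 (0.32 log units; beyond the scatter), though a single example gives only weak grounds. Compound 4 is therefore estimated at 3600 nM, plausibly between 1800 nM and 7500 nM.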

Compound 4, half-maximal inhibitory concentration: 2800 nM
For compound 4 the middle estimate is 1.3-fold (0.11 log units) above the measured one; the measured number falls inside the stated range.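

In this assay, putting 4-acetamidophenyl in place of thiophen-2-yl on the sulfonyl sulfur again gives a lower number, with a 2.7-fold lower number from compound 3 to compound 4 (0.42 log units; beyond the scatter). The change carried over from the core of compound 1 to the core of compound 3 with much the same size: the same change on two cores in this assay, a 2.1-fold lower number (0.32 log units; beyond the scatter) from compound 1 to compound 2 and a 2.7-fold lower number (0.42 log units; beyond the scatter) from compound 3 to compound 4, 1.3-fold (0.10 log units) apart, within the scatter of two such steps. Within the data shown here, this agreement rests on only two matched pairs, on two similar cores and in one cell line; it does not show that the step would hold on a more different core, and it does not explain why the number falls.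

The compounds shown leave open whether other groups on the sulfonyl sulfur, such as a plain phenyl or a phenyl carrying a free amine, would give a step of similar size on both cores. They also leave open whether the step would survive replacing the boronic acid with a carboxylic acid, or using a longer chain on the sulfur of the core.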